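The source may hold more compounds than are shown below. What is called first, only, known or untested is meant among the compounds shown, and "the series" means these compounds.

Measured so far in this series:
compound 1 `CCOC(=O)c1ccc(NC(=O)CCc2cccc3c2B(O)OC3)cc1`: > 100000 nM
compound 2 `C#Cc1ccccc1NC(=O)CCc1cccc2c1B(O)OC2`: 18000 nM
compound 3 `O=C(CCc1cccc2c1B(O)OC2)Nc1cccc(-c2cccc(F)c2)c1`: 37000 nM

Three amides of the shared core have been run in an ADME assay on WI-38 cells (Homo sapiens) for cytotoxicity, read by MTT assay, with a stated time of 72 h; a lower number here means a stronger inhibitor, a higher number a weaker inhibitor. Compound 1 gives no number in this assay, only > 100000 nM, which is a limit of the assay; this is the limit of > 100000 nM in this assay, at which 1 of the 3 values shown sits. Compound 2 gives 18000 nM in this assay, and compound 3 gives 37000 nM. Of the two numbers, compound 3 stands highest; compound 2 is nearest, with a lower number, and that gap is beyond the scatter. All three compounds show only weak cytotoxicity in this assay.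

Compound 4 `CC(=O)c1cccc(-c2cccc(NC(=O)CCc3cccc4c3B(O)OC4)c2)c1` has not yet been measured in this assay. It differs from compound 3 by acetyl in place of fluoro on an aromatic carbon. Within the data shown here, no step between measured compounds matches this change, so no measured step can be drawn on. Given the weak values of compound 2 and compound 3 in this assay, compound 4 is expected to stay close to compound 3, and the step of a 1.1-fold higher number from compound 3 to compound 4 (0.03 log units; within the scatter) is expected to fall within the scatter. Compound 4 is expected to give about 40000 nM in this assay, estimated to lie between 15000 nM and 100000 nM.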

Compound 4, half-maximal inhibitory concentration: 2200 nM
The estimate for compound 4 lay 18-fold (1.26 log units) above the measured number; measured number below the stated range.
By their numbers in this assay, from the lowest: compound 4; then compound 2; then compound 3. At a limit, above all of these: compound 1.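

Acetyl in place of fluoro on an aromatic carbon, meta to a large group, gives a 17-fold lower number from compound 3 to compound 4 (1.23 log units; beyond the scatter) in this assay. This position is therefore not indifferent to what it carries, and a single change here is enough to move a weakly cytotoxic amide of the shared core by a large step. Nothing measured on these compounds accounts for the size of this step.

On these data alone, whether the step belongs to the carbonyl or to the acetyl group as a whole stays open, and an amine, a carboxylic acid or a 1-hydroxyethyl group at the same place would help to separate the two. Among these compounds, with only one pair in hand, it also stays open whether the same change would give a similar step on other amides of the shared core.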